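Adding a ring methyl: compound 2 to compound 4

The source may report more compounds than this note shows. Statements on the series, on what has been measured and on what is new or still open speak of the compounds shown alone.

- compound 1 (`CCCCCCCCCCN1CCCC(C(=O)N2CCN(C(=O)C3CCCN(CCCCCCCCCC)C3)CC2)C1`) gives 16000 nM
- compound 2 (`CCCCCCCCCCN1CCCC(C(=O)N2CCN(C(=O)C3CCCN(CCCCCCCCCC)C3)C(C)C2)C1`) gives 20900 nM
- compound 3 (`CCCCCCCCCCN1CCCC(C(=O)N2CC(C)N(C(=O)C3CCCN(CCCCCCCCCC)C3)CC2C)C1`) gives 23800 nM

All three values come from a functional assay for inhibition, with Homo sapiens as the target (a higher number here means a weaker inhibitor, a lower number a stronger inhibitor), and lie close together. Compound 2 sits within the scatter of both compound 1 and compound 3, so no order can be drawn around it on these numbers.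

Compound 4 (`CCCCCCCCCCN1CCCC(C(=O)N2CC(C)N(C(=O)C3CCCN(CCCCCCCCCC)C3)C(C)C2)C1`) has not been measured. It departs from compound 2 by a single change (methyl in place of hydrogen on a saturated ring carbon), methyl in place of hydrogen on a saturated ring carbon.

Two measured steps are of the same kind and bear on it. The steps of a 1.3-fold higher number from compound 1 to compound 2 (0.12 log units; within the scatter) and a 1.1-fold higher number from compound 2 to compound 3 (0.06 log units; within the scatter) are both small, and neither leaves the scatter. Within the data shown here, no measured compound carries the methyl groups in the arrangement of compound 4, so the range is kept wide.

In this assay no step beyond the scatter is therefore expected, and no direction can be given. The expected step is a 1.1-fold higher number from compound 2 to compound 4 (0.02 log units; within the scatter) on this estimate. Compound 4 is estimated at 22000 nM with an expected range from 12000 nM to 40000 nM in this read-out.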

Compound 4, half-maximal inhibitory concentration: 22900 nM
Compound 4: middle estimate off by 1.0-fold (0.02 log units), on the low side; the measured number falls inside the stated range.
By their numbers in this assay, from the lowest: compounds 1, 2, 4 and 3 (each within the scatter of the next).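

In this assay, methyl in place of hydrogen on this saturated ring carbon, next to the ring nitrogen and two ring bonds from the ring atom that bears a methyl group, gives a 1.1-fold higher number from compound 2 to compound 4 (0.04 log units; within the scatter), so this position joins the two earlier ring-methyl steps, a 1.3-fold higher number from compound 1 to compound 2 (0.12 log units; within the scatter) and a 1.1-fold higher number from compound 2 to compound 3 (0.06 log units; within the scatter), in staying within the scatter. The new compound also allows a comparison of two methyl arrangements on the ring: compound 3 gives 23800 nM and compound 4 gives 22900 nM, values within the scatter of each other, so these two arrangements are not separated on these numbers. No measurement is available that could account for this flat picture, and no cause is offered.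

The compounds shown leave open whether anything other than methyl at this ring carbon, such as an ethyl group, a hydroxymethyl group, an amine or a carboxylic acid, would produce a step beyond the scatter. Among these compounds, they also leave open whether any ring substitution can move the number appreciably while both long chains remain in place, since every step so far is a methyl in place of hydrogen.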